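The source may hold more compounds than are shown below. What is called first, only, known or untested is meant among the compounds shown, and "the series" means these compounds.

In an ADME assay on HeLa cells (Homo sapiens) for cytotoxicity, read by MTT assay (a higher number here means a weaker inhibitor, a lower number a stronger inhibitor), compound 3 `COc1ccc(C[C@H]2COC(=O)[C@@H]2Cc2ccc(OCC(=O)N3CCCC3)c(OC)c2)cc1OC` stands only at a limit, >= 600000 nM. Compound 2 `COc1ccc(C[C@H]2COC(=O)[C@@H]2Cc2ccc(OCc3cn(-c4ccc(C)cc4)nn3)c(OC)c2)cc1OC` is likewise a limit, >= 600000 nM. Compound 1 `COc1ccc(C[C@H]2COC(=O)[C@@H]2Cc2ccc(OCc3cn(-c4ccc(Br)cc4)nn3)c(OC)c2)cc1OC` gives a number, 128000 nM. Compound 4 `COc1ccc(C[C@H]2COC(=O)[C@@H]2Cc2ccc(OCc3cn(Cc4ccccc4)nn3)c(OC)c2)cc1OC` differs from compound 3 by 1-benzyl-1H-1,2,3-triazol-4-yl in place of (pyrrolidin-1-yl)carbonyl on a saturated chain carbon bound to an oxygen on an aromatic ring, with 1-benzyl-1H-1,2,3-triazol-4-yl in place of (pyrrolidin-1-yl)carbonyl on a saturated chain carbon bound to an oxygen on an aromatic ring. Two readings pull apart: an at least 4.6-fold higher number from compound 1 to compound 3 (0.67 log units; beyond the scatter) lies beyond the scatter, yet a step that the two limits leave unreadable from compound 2 to compound 3 cannot be sized, and an at least 4.6-fold higher number from compound 1 to compound 2 (0.67 log units; beyond the scatter) also lies beyond the scatter. Compound 4 carries neither bromo nor methyl, so only a modest fall in the number is expected, and possibly none that can be read. The expected step is an at least 2.0-fold lower number from compound 3 to compound 4 (0.30 log units; that floor lies within the scatter). Compound 4 is estimated at 300000 nM, within 110000 nM to 700000 nM.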

Compound 4, half-maximal inhibitory concentration: 346000 nM
The estimate for compound 4 lay 1.2-fold (0.06 log units) below the measured number, and the stated range covers the measured number.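

In this assay, as far as these compounds go, the triazole compounds now hold a second measured number: benzyl in place of 4-bromophenyl on the aromatic nitrogen gives a 2.7-fold higher number from compound 1 to compound 4 (0.43 log units; beyond the scatter). 1-Benzyl-1H-1,2,3-triazol-4-yl in place of (pyrrolidin-1-yl)carbonyl gives an at least 1.7-fold lower number from compound 3 to compound 4 (0.23 log units; that floor lies within the scatter), and benzyl in place of 4-methylphenyl gives an at least 1.7-fold lower number from compound 2 to compound 4 (0.23 log units; that floor lies within the scatter), so the true size of each of these two steps remains unknown. Both start from a limit rather than a number: the limit of >= 600000 nM in this assay, at which 2 of the 4 values shown sit.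

Still open, from the compounds shown here alone, is how an amine, a carboxylic acid or a longer carbon chain in place of benzyl on the aromatic nitrogen would read in this assay.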